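This account rests on a few compounds, and the source may have more. Where it says the series, first, only, none or still open, it means among the compounds named here.

Compound 2 `CN(C)C(=O)C(=O)CCc1ccc(Cl)cc1` shares its core with compound 1 `O=C(CCc1ccc(Cl)cc1)C(=O)N1CCCCC1`; the two differ only in the group on one carbonyl carbon, a dimethylamino in compound 2 where compound 1 carries a piperidin-1-yl. In an assay on HEK-293T cells for inhibition of phospholipase A and acyltransferase 4 (Homo sapiens), with stated times of 30 min and 20 min (on this read-out lower numbers stand for stronger inhibition and higher numbers for weaker inhibition), compound 1 gives > 10000 nM, which is a limit of the assay and not a number. In this assay compound 2 gives > 10000 nM, again a limit rather than a number. The step from compound 1 to compound 2 is therefore a step that the two limits leave unreadable from compound 1 to compound 2. Both values sit at the limit of > 10000 nM in this assay, at which 2 of the 2 values shown sit, so compound 2 stands at the edge of what this assay can read, with no measured number to place it more precisely.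

Compound 3 `O=C(CCc1ccc(Cl)cc1)C(=O)N1CCOCC1` is made from compound 2 by a single change: morpholin-4-yl in place of dimethylamino on a carbonyl carbon. For the measured compounds named here, the only step so far that bears on it, the exchange of one amide substituent for another, could not be read in size, and both of its compounds stayed at the limit. Going by the values given here, no step of readable size is therefore available to set a direction, and the expectation rests on the two limits alone. Compound 3 is expected to remain at the limit as well, so the estimated step from compound 2 to compound 3 is a step that the limit leaves unreadable from compound 2 to compound 3. Compound 3 is estimated to give 20000 nM in this assay, with a range from 5000 nM to 100000 nM.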

Compound 3, half-maximal inhibitory concentration: > 10000 nM
Compound 3 was reported as a limit; the forecaster's own chance of this, stated with the estimate: 85%; the middle value lies beyond the limit too.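

Compound 3, like compound 1 and compound 2, gives a limit and not a number, so none of the steps among these three compounds can be read in size: the limit of > 10000 nM in this assay, at which 3 of the 3 values shown sit.

The compounds shown leave open whether any group on this carbonyl carbon could bring a value that this assay can read as a number.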